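A few compounds are considered here, and "the series" means these few. Any claim that something is new, unique, unknown or untested is made for them only; others in the source may bear on it.

Measured so far:
compound 1, `C=CS(=O)(=O)N1CCN(c2ncnc3sc(-c4ccc(OC)cc4)cc23)CC1`, gives 29900 nM
compound 2, `C=CS(=O)(=O)N1CCN(c2ncnc3sc(-c4ccc(C#N)cc4)cc23)CC1`, gives 8050 nM
compound 3, `COc1ccc(NC(=O)N2CCN(c3ncnc4sc(-c5ccc(N6CCN(C)CC6)cc5)cc34)CC2)cc1`, gives 20900 nM

These numbers come from a functional assay on MDA-MB-231 cells (Homo sapiens) for antiproliferative activity, read by MTT assay, with a stated time of 48 h; on this read-out higher numbers stand for weaker inhibition and lower numbers for stronger inhibition. Compound 1 and compound 2 differ by cyano in place of methoxy on an aromatic carbon, and that change made a 3.7-fold lower number from compound 1 to compound 2 (0.57 log units; beyond the scatter). How the core of compound 3 differs from the core of compound 1 is not broken down here. Compound 4, `CN1CCN(c2ccc(-c3cc4c(N5CCN(C(=O)Nc6ccc(C#N)cc6)CC5)ncnc4s3)cc2)CC1`, is not yet measured in this assay; it differs from compound 3 by cyano in place of methoxy on an aromatic carbon. This is the same change as before, but the ring that carries it belongs to a (4-methoxyphenyl)carbamoyl group in compound 3, whereas in compound 1 it is the 4-methoxyphenyl on the core. For the measured compounds named here, a smaller step is expected from compound 3 to compound 4, a 2.3-fold lower number from compound 3 to compound 4 (0.37 log units; beyond the scatter), because the only guide is a 3.7-fold lower number from compound 1 to compound 2 (0.57 log units; beyond the scatter) on a different core and at a different attachment. Compound 4 is therefore estimated at 9000 nM, likely between 3000 nM and 30000 nM.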

Compound 4, half-maximal inhibitory concentration: 3930 nM
Compound 4: the middle estimate sits 2.3-fold (0.36 log units) above what was measured; the range from low to high includes it.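

In this assay, cyano in place of methoxy gave a 5.3-fold lower number from compound 3 to compound 4 (0.73 log units; beyond the scatter), so the number fell again, as it had in the earlier pair. Set side by side, the two steps agree: the same change on two cores in this assay, a 3.7-fold lower number (0.57 log units; beyond the scatter) from compound 1 to compound 2 and a 5.3-fold lower number (0.73 log units; beyond the scatter) from compound 3 to compound 4, 1.4-fold (0.16 log units) apart, within the scatter of two such steps. The change therefore carried over between these two cores, even with the ring bearing it attached at a different point, but two pairs are a small sample and do not explain why the number falls or show that it would on other cores.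

Still open, on these data alone, is whether an amine, a carboxylic acid or a trifluoromethyl group in place of methoxy would lower the number as cyano does.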